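A few compounds are considered here, and "the series" means these few. Any claim that something is new, unique, unknown or untested is made for them only; others in the source may bear on it.

Compound 3, `Cc1cc(COc2cccc(F)c2)nc(-c2ccccn2)n1`, is measured in a functional assay on cells for antagonist activity at Free fatty acid receptor 1 (Homo sapiens), read by TR-FRET and inositol phosphate accumulation, with a stated time of 2 h (a higher number here means a weaker inhibitor, a lower number a stronger inhibitor), where compound 3 gives 794 nM. Among the two numbers available, this is the highest. For the measured compounds named here, its closest neighbour is compound 1, `Cc1cc(COc2cccc(Cl)c2)nc(-c2ccccn2)n1`, which in this assay gives 398 nM; the step of a 2.0-fold higher number from compound 1 to compound 3 (0.30 log units; within the scatter) is the only one-place change measured here. Compound 2, `Cc1cc(COc2ccc(S(C)(=O)=O)cc2)nc(-c2ccccn2)n1`, gives only a limit in this assay, > 39800 nM, consistent with the limit of > 39800 nM in this assay, at which 1 of the 3 values shown sits.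

Compound 4, `Cc1cc(COc2ccc(F)cc2)nc(-c2ccccn2)n1`, differs from compound 3 by 4-fluorophenyl in place of 3-fluorophenyl on an oxygen on a saturated carbon. Going by the values given here, no measured step moves a group around the ring in this way, so the step from compound 1 to compound 3, which swaps one halogen for another, does not bear directly on it. With nothing closer to lean on, the expected change from compound 3 to compound 4 is estimated as a 1.9-fold higher number from compound 3 to compound 4 (0.28 log units; within the scatter), toward a weaker inhibitor but modest. Compound 4 is therefore expected to give about 1500 nM in this assay, within a range from 400 nM to 6000 nM.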

Compound 4, half-maximal inhibitory concentration: 631 nM
Beside the measured number, compound 4's estimate is 2.4-fold (0.38 log units) above it, within the range that was stated.
By their numbers in this assay, from the lowest: compounds 1, 4 and 3 (each within the scatter of the next). At a limit, above all of these: compound 2.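

In this assay, moving the fluoro around the ring gives a 1.3-fold lower number from compound 3 to compound 4 (0.10 log units; within the scatter), and replacing 3-chlorophenyl with 4-fluorophenyl gives a 1.6-fold higher number from compound 1 to compound 4 (0.20 log units; within the scatter), so the three halogen-bearing phenyl groups on this oxygen cannot be told apart here. A much larger difference appears when fluoro takes the place of methylsulfonyl on the same aromatic carbon, with an at least 63-fold lower number from compound 2 to compound 4 (1.79 log units; beyond the scatter), which ties the poor result to methylsulfonyl rather than to having a group on that carbon at all. That step has only a lower bound, since compound 2 gives a limit and not a number: the limit of > 39800 nM in this assay, at which 1 of the 4 values shown sits.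

The compounds shown leave open whether a methyl or methoxy group on this phenyl ring would read like the halogens. Going by these compounds, it also remains open whether an amine or a carboxylic acid there would behave like methylsulfonyl.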